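A Rhodanine Substituent Swap in a Peptide Series

The source may hold more compounds than are shown below. What is called first, only, known or untested is meant among the compounds shown, and "the series" means these compounds.

This study follows a short peptide-like series through an ADME assay for permeability, using PAMPA; a higher number here means that the compound crosses the layer faster, a lower number that the compound crosses the layer more slowly. Among the measured compounds shown here, compound 1 `CCCCC(C(=O)OC)N1C(=O)/C(=C/c2ccc(C(=O)N[C@@H](CCCNC(=N)N)C(=O)N[C@@H](CCCCN)C(=O)N[C@@H](CCCC)C(N)=O)cc2)SC1=S` is the only member with a measured number: in this assay compound 1 gives 0.87 10^-6 cm/s. Two related compounds give no number at all. Compound 2 `CCCC[C@H](NC(=O)[C@H](CCCCN)NC(=O)[C@H](CCCNC(=N)N)NC(=O)c1ccccc1)C(N)=O` is recorded in this assay as "impermeable" (no number reported). Compound 3 `CCCC[C@H](NC(=O)[C@H](CCCCN)NC(=O)[C@H](CCCNC(=N)N)NC(=O)c1ccc(/C=C/C(N)=O)cc1)C(N)=O` is recorded in this assay as "impermeable" (no number reported). So compound 1 stands alone as the one entry that crosses the layer at a measurable rate, while the others do not.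

Compound 4 `CCCC[C@H](NC(=O)[C@H](CCCCN)NC(=O)[C@H](CCCNC(=N)N)NC(=O)c1ccc(/C=C2\SC(=S)N(Cc3ccc(OC)cc3)C2=O)cc1)C(N)=O` keeps the shared core of compound 1 and differs only at one position: 4-methoxybenzyl in place of 1-(methoxycarbonyl)pentyl on an amide-type nitrogen in a ring. For the measured compounds named here, no measured pair in this set shows what such a swap does to permeability, so the direction cannot be read from the data. The expectation is that the step of a 1.1-fold lower number from compound 1 to compound 4 (0.04 log units; within the scatter) stays within the usual scatter, with no clear move in either direction. For compound 4 in this assay the estimate is 0.8 10^-6 cm/s, with a range from 0.3 10^-6 cm/s to 1.8 10^-6 cm/s.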

Compound 4, apparent permeability: 0.6 10^-6 cm/s
Beside the measured number, compound 4's estimate is 1.3-fold (0.12 log units) above it; the measured number falls inside the stated range.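

Placing 4-methoxybenzyl in place of 1-(methoxycarbonyl)pentyl on the amide-type nitrogen in a ring gives, in this assay, a 1.5-fold lower number from compound 1 to compound 4 (0.16 log units; within the scatter) as the first measured step at this position. A group with no ring and a group holding a six-membered aromatic ring, each of 9 heavy atoms, can therefore be exchanged here with both compounds keeping a measurable number and no change beyond the scatter. Nothing measured here explains this result.

On these data alone, what an amine or a carboxylic acid on this nitrogen would do to the number stays open, as does the effect of a longer chain. As far as these compounds go, with a single step at this position, it also remains open whether other groups on the shared core would stay within the scatter.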